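Swapping Fluoro for Nitro on a Shared Core

The compounds below may be only part of what the source reports. "The series", "measured", "known", "first", "only" and "open" are said of these compounds alone.

Of the compounds shown here, three built on a shared core have been measured in a functional assay on BT-20 cells (Homo sapiens) for antiproliferative activity, read by trypan blue exclusion; a lower number here means a stronger inhibitor, a higher number a weaker inhibitor. Compound 1, `COc1cc(OC)c(/C=C/S(=O)(=O)Cc2cc(OC)c(OC)c(OC)c2)c(OC)c1`, reaches only a limit in this assay, > 20000 nM. Compound 2, `COc1cc(OC)c(/C=C/S(=O)(=O)Cc2ccc(Cl)cc2)c(OC)c1`, gives 10000 nM in this assay. Compound 3, `COc1ccc(CS(=O)(=O)/C=C/c2ccc(F)cc2)cc1`, gives 1500 nM in this assay, which is the lowest of the two numbers reported; the nearest number, that of compound 2, sits higher by a margin beyond the usual scatter. No pair among these compounds differs in a single place, so no measured step is available to guide a prediction.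

Compound 4, `COc1ccc(CS(=O)(=O)/C=C/c2ccc([N+](=O)[O-])cc2)cc1`, is the untested member. Relative to compound 3 the change is nitro in place of fluoro on an aromatic carbon. Among the measured compounds shown here, with no measured step of this kind to lean on, the direction of any change from compound 3 to compound 4 remains open. In this assay compound 4 is estimated at 2000 nM, with a range from 500 nM to 8000 nM. The step of a 1.3-fold higher number from compound 3 to compound 4 (0.12 log units; within the scatter) that this estimate implies is expected to stay within, or only slightly beyond, the scatter of repeated measurements.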

Compound 4, half-maximal inhibitory concentration: 5000 nM
Compound 4: middle estimate off by 2.5-fold (0.40 log units), on the low side; low and high end bracket the measured number.
By their numbers in this assay, from the lowest: compound 3; then compounds 4 and 2 (each within the scatter of the next). At a limit, above all of these: compound 1.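

In this assay, among the compounds shown here, the step of a 3.3-fold higher number from compound 3 to compound 4 (0.52 log units; beyond the scatter) is the first measured change at a single place, which gives the position a direct reading that compounds 1 and 2 could not provide. On this aromatic carbon, para to a large group, the fluoro group gives the lower number of the pair, while the nitro group, with more heavy atoms and two hydrogen-bond acceptors, costs a modest amount of activity without abolishing it. Nothing measured here explains why the number rises with this change.

From the compounds shown here alone, a single step between two groups gives no trend at this position, so it remains open whether an amine, a carboxylic acid or a nitrile on the same aromatic carbon would give a number close to that of compound 3, close to that of compound 4, or far from both. Going by these compounds, it is also open whether the same exchange of fluoro for nitro would produce a step of similar size and direction on the more heavily substituted core of compound 1.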